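The source may hold more compounds than are shown below. What is called first, only, known or untested is meant among the compounds shown, and "the series" means these compounds.

Measured in a functional assay on HeLa cells (Homo sapiens) for antiproliferative activity, read by MTT assay, with a stated time of 72 h; a higher number here means a weaker inhibitor, a lower number a stronger inhibitor:
- Compound 1 `COc1cccc(N2C(=O)COc3ccc(-c4cnc(OC)c(NS(=O)(=O)c5ccc(F)cc5)c4)cc32)c1`: > 40000 nM (a limit)
- Compound 2 `O=C1COc2ccc(-c3cccc(NS(=O)(=O)c4ccc(F)cc4)c3)cc2N1c1ccccc1`: 17700 nM
- Compound 3 `O=C1COc2ccc(-c3cccc(NS(=O)(=O)c4ccc(F)cc4)c3)cc2N1C1CC1`: > 40000 nM (a limit)

Compound 3 gives > 40000 nM, which is a limit and not a number. Its true standing in this assay is therefore unknown, and it offers only a weak starting point.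

Compound 4 `O=C1COc2ccc(-c3cccc(NS(=O)(=O)c4ccc(F)cc4)c3)cc2N1c1ccc(F)cc1` has 4-fluorophenyl in place of the cyclopropyl of compound 3, on an amide-type nitrogen in a ring: 4-fluorophenyl in place of cyclopropyl on an amide-type nitrogen in a ring.

For the measured compounds named here, one measured step bears directly on this change: an at least 2.2-fold higher number from compound 2 to compound 3 (0.35 log units; beyond the scatter). That step put cyclopropyl in place of phenyl at the same nitrogen, and it lies beyond the scatter. The change to compound 4 runs the opposite way, so a lower number is expected. Compound 4 regains an aromatic six-membered ring there, so it is expected to land near compound 2 at 17700 nM.

A caution comes from compound 1, which also carries a substituted phenyl on that nitrogen but has a different core. Compound 1 gives > 40000 nM, which is a limit.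

The expected change is an at least 2.2-fold lower number from compound 3 to compound 4 (0.34 log units; beyond the scatter), and it may be modest. Compound 4 is estimated at 18000 nM, with an expected range of 8000 nM to 40000 nM.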

Compound 4, half-maximal inhibitory concentration: > 40000 nM
Compound 4 was reported as a limit; the forecaster's own chance of this, stated with the estimate: 30%; middle value at least 2.2-fold (0.34 log units) from the limit.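

For the compounds shown here, the phenyl group on this amide-type nitrogen proves less forgiving than the earlier compounds could show: in this assay, fluoro in place of hydrogen on an aromatic carbon gives an at least 2.2-fold higher number from compound 2 to compound 4 (0.35 log units; beyond the scatter). An aromatic six-membered ring at this place is therefore not enough on its own to give a measurable value, and the step from cyclopropyl to 4-fluorophenyl cannot be read, as both of its ends are limits. Compound 2 is the only compound shown with a true number, and the other compounds all stop at the same point: the limit of > 40000 nM in this assay, at which 3 of the 4 values shown sit.

Going by these compounds, how far past that limit compound 4 really lies stays open, so the size of the fluoro step is known only as a minimum. Also open, on these data alone, is whether a chlorine, a methyl or an amine on the phenyl ring, or a longer chain such as benzyl on the ring nitrogen, would give a lower number than compound 2 at 17700 nM.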